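This account rests on a few compounds, and the source may have more. Where it says the series, first, only, none or still open, it means among the compounds named here.

Among the measured compounds shown here, compound 2 `COc1cc2c(cc1OC)C(CC(=O)Nc1ccccn1)CC2` gives 48.1% in a functional assay on the whole organism (strain Swiss Albino) for inhibition, with Mus musculus as the target, in the writhing test, with a stated time of 1 h, at a dose of 100 mg/kg by the oral route; a higher number here means more inhibition at the dose given (going by the name of the read-out), a lower number less inhibition; it is one of only two numbers in hand, the other belonging to compound 1 `COc1cc2c(cc1OC)C(CC(=O)Nc1cccc(C)c1)CC2`, which gives 54.3%, and a number 6.2 percentage points lower from compound 1 to compound 2 (within the scatter). Compound 3 `COc1cc2c(cc1OC)C(CC(=O)Nc1ccncc1)CC2` differs from compound 2 by pyridin-4-yl in place of pyridin-2-yl on an amide-type nitrogen. For the measured compounds named here, the only measured step that touches the aryl group on the amide nitrogen is the one from compound 1 to compound 2, and it stayed within the scatter; no measured pair separates the two pyridyl isomers. A step no larger than the scatter is therefore expected, a number 1.1 percentage points lower from compound 2 to compound 3 (within the scatter). Compound 3 is expected to give 47%, within 32% to 62%.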

Compound 3, a percentage reported as inhibition, in the whole organism at one dose (the size of the read-out at that dose, not a potency): 60.1%
Beside the measured number, compound 3's estimate is 13.1 percentage points below it, and the stated range covers the measured number.
By their numbers in this assay, from the lowest: compounds 2, 1 and 3 (each within the scatter of the next, the first and the last beyond it).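

In this assay, among the compounds shown here, pyridin-4-yl in place of pyridin-2-yl on the amide-type nitrogen gives a number 12 percentage points higher from compound 2 to compound 3 (beyond the scatter) and is the first step to pass the scatter, so two isomers with the same atoms are not interchangeable at this place. Pyridin-4-yl in place of 3-methylphenyl gives a number 5.8 percentage points higher from compound 1 to compound 3 (within the scatter) and does not separate the two compounds. Nothing at hand explains the gap between the isomers.

Open, going by these compounds, is whether pyridin-3-yl would fall with pyridin-4-yl or with pyridin-2-yl. Also open, on these data alone, is what an amine on the pyridine ring would do to the number.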